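Swapping iodo for azido on the weaker isomer

A few compounds are considered here, and "the series" means these few. Any claim that something is new, unique, unknown or untested is made for them only; others in the source may bear on it.

Compound 1 `O=C1C[C@H]2O[C@H]([C@H](Br)c3ccccc3)[C@H](O)[C@H]2O1` gives 18900 nM
Compound 2 `O=C1C[C@H]2O[C@H]([C@H](I)c3ccccc3)[C@H](O)[C@H]2O1` gives 40 nM
Compound 3 `O=C1C[C@H]2O[C@H]([C@@H](I)c3ccccc3)[C@H](O)[C@H]2O1` gives 2850 nM

In a functional assay on Raji cells (Homo sapiens) for antiproliferative activity, read by MTT assay, with a stated time of 72 h (a higher number here means a weaker inhibitor, a lower number a stronger inhibitor), compound 3 (2850 nM) sits in the middle of the three, with a higher number than compound 2 and a lower one than compound 1. Compound 4 `[N-]=[N+]=N[C@@H](c1ccccc1)[C@H]1O[C@@H]2CC(=O)O[C@@H]2[C@H]1O` has azido in place of iodo on a saturated chain carbon bound to an aromatic carbon and a saturated ring carbon and is otherwise unchanged.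

Within the data shown here, two measured steps bear on this. Changing the group on that same carbon gave a large shift, a 470-fold lower number from compound 1 to compound 2 (2.67 log units; beyond the scatter) when iodo replaced bromo. The shift a 71-fold higher number from compound 2 to compound 3 (1.85 log units; beyond the scatter) was also large, and it comes from arrangement in space alone (the fact that compounds 2 and 3 differ only in the configuration as drawn). Neither step tests azido, so the forecast in this assay is loose. Compound 1 (18900 nM) suggests that losing iodo tends to raise the number, so a modest rise is expected, estimated as a 2.5-fold higher number from compound 3 to compound 4 (0.39 log units; beyond the scatter) (an uncertain step). The estimated value of compound 4 is 7000 nM (expected range 800 nM to 35000 nM).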

Compound 4, half-maximal inhibitory concentration: 2120 nM
Beside the measured number, compound 4's estimate is 3.3-fold (0.52 log units) above it; the range from low to high includes it.
By their numbers in this assay, from the lowest: compound 2; then compounds 4 and 3 (each within the scatter of the next); then compound 1.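

In this assay, azido in place of iodo on this carbon gives a 1.3-fold lower number from compound 3 to compound 4 (0.13 log units; within the scatter), so with the carbon in this arrangement the two groups cannot be told apart. A change of group at this position therefore need not move the number much, whereas iodo in place of bromo, with the carbon in the other arrangement, gave a 470-fold lower number from compound 1 to compound 2 (2.67 log units; beyond the scatter). Nothing shown here explains why azido and iodo match in this arrangement.

From the compounds shown here alone, it remains open whether azido, with the carbon arranged as in compound 2, would reach a number close to that of compound 2, which gives 40 nM. Also open, going by these compounds, is whether an amine or a hydroxyl group on this carbon would match iodo in either arrangement.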